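Fluoro to chloro at the limit of the assay

The source may report more compounds than this note shows. Statements on the series, on what has been measured and on what is new or still open speak of the compounds shown alone.

In a functional assay on Jurkat cells (Homo sapiens) for antiproliferative activity, read by MTT assay, with a stated time of 72 h (on this read-out higher numbers stand for weaker inhibition and lower numbers for stronger inhibition), the measured compounds stand as follows
Compound 1 `COc1cc(-n2ncnc2-c2ccc(Cl)cc2)cc(OC)c1OC` gives > 10000 nM, a limit
Compound 2 `COc1cc(-c2ncnn2-c2ccc(F)cc2)cc(OC)c1OC` gives > 10000 nM, a limit
Compound 3 `COc1cc(-n2ncnc2-c2ccc(OC(F)(F)F)cc2)cc(OC)c1OC` gives > 10000 nM, a limit

Compound 2 offers no number to start from, since its > 10000 nM is a limit and nothing more. The same holds across the series, which shows only (the limit of > 10000 nM in this assay, at which 3 of the 3 values shown sit). Compound 4 `COc1cc(-c2ncnn2-c2ccc(Cl)cc2)cc(OC)c1OC` departs from compound 2 by one change, (chloro in place of fluoro on an aromatic carbon), that is, chloro in place of fluoro on an aromatic carbon, para to a large group. Going by the values given here, the only measured step that bears on this is a step that the two limits leave unreadable from compound 1 to compound 3, which also replaces a group at an aromatic carbon but gives no size to carry over. With no readable step available, no clear shift in this assay is expected and no direction can be favoured. The expected outcome is a step that the limit leaves unreadable from compound 2 to compound 4, and compound 4 is likely to stay near the limit. Compound 4 is estimated at 12000 nM, with an expected range from 5000 nM to 30000 nM.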

Compound 4, half-maximal inhibitory concentration: > 10000 nM
Compound 4: a limit, no number; the forecaster's own chance of this, stated with the estimate: 75%; the middle value does not contradict the limit.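

No new step can be read between compound 2 and compound 4, as both values are limits and not numbers. The compounds shown leave open whether 4-fluorophenyl and 4-chlorophenyl differ at all in this assay, and the series offers only this: the limit of > 10000 nM in this assay, at which 4 of the 4 values shown sit.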